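Aryl-acetylene phenylpropanoic acids: thiophene to pyridine swap

The source may report more compounds than this note shows. Statements on the series, on what has been measured and on what is new or still open speak of the compounds shown alone.

Measured so far, all in an in vitro functional assay on 1321-N1 cells for agonist activity at Free fatty acid receptor 1 (Homo sapiens), read by fluorescence, spectrophotometry and calcium flux; on this read-out lower numbers stand for an effect already at smaller amounts and higher numbers for an effect only at larger amounts of compound:
compound 1 `O=C(O)CCc1ccc(C#Cc2cccs2)cc1`: 251 nM
compound 2 `Cc1cnc(F)c(C#Cc2ccc(CCC(=O)O)cc2)c1`: 661 nM
compound 3 `Cc1cnc(Cl)nc1C#Cc1ccc(CCC(=O)O)cc1`: 4270 nM

Compound 1 gives the lowest number of the three. Compound 2 stands a step higher that lies beyond the scatter, and compound 3 stands far higher again, also beyond the scatter. Compound 4 `O=C(O)CCc1ccc(C#Cc2ccncc2)cc1` has not yet been measured in this assay. It differs from compound 1 in one place: pyridin-4-yl in place of thiophen-2-yl on a triple-bonded carbon, in words, pyridin-4-yl in place of thiophen-2-yl on a triple-bonded carbon. Within the data shown here, no measured pair differs in exactly this way, so the size of the step can only be judged from the spread seen across compounds 1 to 3, where both other groups on the triple-bonded carbon give higher numbers than the thiophen-2-yl of compound 1. For compound 4 a moderate rise in the number is therefore expected, a 3.2-fold higher number from compound 1 to compound 4 (0.50 log units; beyond the scatter). The outcome is thought more likely to land near the number of compound 2 than near that of compound 3. The estimate for compound 4 in this assay is 800 nM, with an expected range from 250 nM to 2500 nM.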

Compound 4, half-maximal effective concentration: 4070 nM
Compound 4: middle estimate off by 5.1-fold (0.71 log units), on the low side; measured number outside the range, above it.
By their numbers in this assay, from the lowest: compound 1; then compound 2; then compounds 4 and 3 (each within the scatter of the next).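

In this assay, the group on the triple-bonded carbon proves far from freely exchangeable: pyridin-4-yl in place of thiophen-2-yl gives a 16-fold higher number from compound 1 to compound 4 (1.21 log units; beyond the scatter), and this is the only pair shown that differs in one place, so the sensitivity of this position can now be read directly rather than inferred from the spread of the series. The step is large even though both groups carry one hetero atom and one hydrogen-bond acceptor, with no net charge, so those counts alone do not keep the number low; what changes is the ring size, from five-membered to six-membered, and the hetero atom, from sulfur to nitrogen. No measurement at hand bears on the reason for the size of this step.

The pair leaves ring size and hetero atom entangled, and a phenyl or a furan-2-yl on the same triple-bonded carbon would help to separate the two. From the compounds shown here alone, it also remains open whether a methyl or a fluorine on the pyridin-4-yl would move the number of compound 4 back towards that of compound 1.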